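A few compounds are considered here, and "the series" means these few. Any claim that something is new, unique, unknown or untested is made for them only; others in the source may bear on it.

Of the compounds shown here, three have been tested so far in a functional assay on HEL cells (Homo sapiens); on this read-out lower numbers stand for higher toxicity in this test and higher numbers for lower toxicity in this test. Compound 1, `CCCCc1cc2cn(COCCO)c(=O)nc2o1`, reaches only a limit there: in this assay compound 1 gives > 200000 nM. Compound 2, `CCCCCc1cc2cn(COCCO)c(=O)nc2o1`, differs from compound 1 by methyl in place of hydrogen on a saturated chain carbon, four bonds along the chain from an aromatic carbon. In this assay compound 2 likewise stands at a limit, > 200000 nM. The step is therefore a step that the two limits leave unreadable from compound 1 to compound 2. Compound 3, `CCCCCc1cc2cn(COCCO)c(O)nc-2n1`, has a different core; how the two cores differ is not broken down here. In this assay compound 3 also stands at a limit, > 200000 nM. All measured values thus share (the limit of > 200000 nM in this assay, at which 3 of the 3 values shown sit). Compound 4, `CCCCCCc1cc2cn(COCCO)c(O)nc-2n1`, is not yet measured; it differs from compound 3 by methyl in place of hydrogen on a saturated chain carbon, five bonds along the chain from an aromatic carbon, the same kind of change as from compound 1 to compound 2, though placed five bonds rather than four bonds along the chain from an aromatic carbon. Within the data shown here, because every value so far sits at the limit of > 200000 nM in this assay, at which 3 of the 3 values shown sit, the step is expected to be a step that the limit leaves unreadable from compound 3 to compound 4, leaving the result near the limit. Compound 4 is accordingly estimated at 300000 nM.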

Compound 4, half-maximal cytotoxic concentration: > 200000 nM
Compound 4 was reported as a limit (the forecaster's own chance of this, stated with the estimate: 85%); the middle value does not contradict the limit.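

Compound 3 and compound 4 both stand at a limit in this assay, and no step between them can be read: the limit of > 200000 nM in this assay, at which 4 of the 4 values shown sit.

The compounds shown leave open where any true value lies past that limit, and whether chain length changes the result in this assay at all.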